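The compounds below may be only part of what the source reports. "The series", "measured", "known", "first", "only" and "open" are said of these compounds alone.

Working notes on the series. The reference point is compound 1 `CN(C)CCn1cnnc1-c1cc(Oc2ccc(NC(=O)N/N=C/c3ccccc3)cc2F)ccn1`, which in a functional assay on A549 cells (Homo sapiens) for cytotoxicity, read by MTT assay, with a stated time of 72 h (a higher number here means a weaker inhibitor, a lower number a stronger inhibitor), gives 1860 nM. Compound 3 `CN(C)CCn1cnnc1-c1cc(Oc2ccc(NC(=O)N/N=C/c3c(O)ccc4ccccc34)cc2F)ccn1` carries the 2-hydroxynaphthalen-1-yl group in place of phenyl; in this assay compound 3 gives 880 nM, and the step of a 2.1-fold lower number from compound 1 to compound 3 (0.33 log units; beyond the scatter) is modest. Compound 2 `Cn1ncnc1-c1cc(Oc2ccc(NC(=O)N/N=C/c3ccccc3)cc2F)ccn1` carries the 1-methyl-1H-1,2,4-triazol-5-yl group in place of the 4-(2-(dimethylamino)ethyl)-4H-1,2,4-triazol-3-yl group. In this assay compound 2 reaches only a limit, > 100000 nM, and no number is known for it. This is the limit described by the limit of > 100000 nM in this assay, at which 1 of the 3 values shown sits, at which compound 2 stands, and the step of an at least 53-fold higher number from compound 1 to compound 2 (1.73 log units; beyond the scatter) is large.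

Compound 4 `Cn1cnnc1-c1cc(Oc2ccc(NC(=O)N/N=C/c3ccccc3)cc2F)ccn1` has not yet been measured. It differs from compound 2 by 4-methyl-4H-1,2,4-triazol-3-yl in place of 1-methyl-1H-1,2,4-triazol-5-yl on an aromatic carbon. Within the data shown here, the only measured step touching this part of the core is the one from compound 1 to compound 2, which was large and combines two changes at once: the ring attachment pattern and the loss of the dimethylaminoethyl chain. Compound 4 keeps the attachment pattern of compound 1 but with a methyl in place of that chain, so it separates the two. An estimate for compound 4 in this assay sits between compound 1 and compound 2: the step of an at least 10-fold lower number from compound 2 to compound 4 (1.00 log units; beyond the scatter) is expected, with a value of about 10000 nM and a range from 2000 nM to 100000 nM, with a real chance that only a limit is reported.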

Compound 4, half-maximal inhibitory concentration: 7560 nM
For compound 4 the middle estimate is 1.3-fold (0.12 log units) above the measured one; low and high end bracket the measured number.
By their numbers in this assay, from the lowest: compound 3; then compound 1; then compound 4. At a limit, above all of these: compound 2.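

The attachment of the triazole matters on its own in this assay: with the same atoms joined differently and the methyl group kept, the change at this carbon next to the ring nitrogen is large (an at least 13-fold lower number from compound 2 to compound 4 (1.12 log units; beyond the scatter)). The dimethylaminoethyl chain therefore does not account for the whole of the earlier large step, since cutting it back to methyl on the 4-methyl-4H-1,2,4-triazol-3-yl attachment gives a modest change (a 4.1-fold higher number from compound 1 to compound 4 (0.61 log units; beyond the scatter)). The step from the 1-methyl-1H-1,2,4-triazol-5-yl compound remains a bound and gives no exact size, as compound 2 stands at a limit: the limit of > 100000 nM in this assay, at which 1 of the 4 values shown sits.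

Open, from the compounds shown here alone, is whether the dimethylamino group itself or the chain length carries the remaining difference, which a propyl chain without an amine or a morpholine at the end of the ethyl chain would separate. Also open is whether the modest gain from 2-hydroxynaphthalen-1-yl carries over to the methyl-bearing triazole, and the compounds shown give no reason for either new step.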